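The compounds below may be only part of what the source reports. "The series", "measured", "known", "first", "only" and "open" are said of these compounds alone.

Working notes on the series. Compound 1 `COc1ccc(/C=C\c2cc(OC)c(OC)c(OC)c2)cc1OCc1ccc(CNC(C)(C)C(=O)O)cc1` carries the shared core with a (1-carboxy-1-methylethyl)amino group on a saturated chain carbon bound to an aromatic carbon. In an ADME assay on HEK293 cells (Homo sapiens) for cytotoxicity, read by CCK-8 assay, with a stated time of 48 h (on this read-out lower numbers stand for stronger inhibition and higher numbers for weaker inhibition), compound 1 gives > 50000 nM, which is a limit of the assay and not a number. Compound 2 `COc1ccc(/C=C\c2cc(OC)c(OC)c(OC)c2)cc1OCc1ccc(CN2C[C@H](O)C[C@@H]2C(=O)O)cc1` in this assay gives > 50000 nM, likewise a limit. Compound 3 `COc1ccc(/C=C\c2cc(OC)c(OC)c(OC)c2)cc1OCc1ccc(CN2CC[C@H](C(=O)O)C2)cc1` in this assay gives > 50000 nM, again a limit. The steps a step that the two limits leave unreadable from compound 1 to compound 2, a step that the two limits leave unreadable from compound 1 to compound 3 and a step that the two limits leave unreadable from compound 2 to compound 3 cannot be sized because of the limit of > 50000 nM in this assay, at which 3 of the 3 values shown sit. Compound 4 `COc1ccc(/C=C\c2cc(OC)c(OC)c(OC)c2)cc1OCc1ccc(CO)cc1` differs from compound 1 by hydroxy in place of (1-carboxy-1-methylethyl)amino on a saturated chain carbon bound to an aromatic carbon. Going by the values given here, no measured step bears directly on this change: the three known steps all lie among compounds 1, 2 and 3, and none has a readable size, so they give no direction. For compound 4 the expectation is only that it stays near the same region, with an at least 1.2-fold lower number from compound 1 to compound 4 (0.09 log units; that floor lies within the scatter) expected to be small. Compound 4 is estimated at 40000 nM in this assay, within 10000 nM to 100000 nM.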

Compound 4, half-maximal inhibitory concentration: 37000 nM
Beside the measured number, compound 4's estimate is 1.1-fold (0.03 log units) above it; low and high end bracket the measured number.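

Compound 4 is the only compound shown with a readable number in this assay, so this saturated chain carbon bound to an aromatic carbon now has one measured value rather than limits alone. Hydroxy in place of (1-carboxy-1-methylethyl)amino gives an at least 1.3-fold lower number from compound 1 to compound 4 (0.13 log units; that floor lies within the scatter), hydroxy in place of 3-carboxypyrrolidin-1-yl gives an at least 1.3-fold lower number from compound 3 to compound 4 (0.13 log units; that floor lies within the scatter), and hydroxy in place of 2-carboxy-4-hydroxypyrrolidin-1-yl gives an at least 1.3-fold lower number from compound 2 to compound 4 (0.13 log units; that floor lies within the scatter). These three steps are floors only, and their full sizes and the steps among compounds 1, 2 and 3 cannot be read because of a ceiling: the limit of > 50000 nM in this assay, at which 3 of the 4 values shown sit.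

The compounds shown leave open whether a simple primary amine or a carboxylic acid on this carbon would give a readable number like that of compound 4 or reach the limit seen for compound 1. Going by these compounds, a longer chain carrying the hydroxy group also remains open.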